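The compounds below may be only part of what the source reports. "The series", "measured", "known", "first", "only" and "open" are said of these compounds alone.

Of the compounds shown here, two have been measured so far in a physicochemical assay for lipophilicity, at pH 7.4; a lower number here means a more polar compound, a higher number a more lipophilic compound. Compound 1 `O=C(Nc1ccc2[nH]ccc2n1)[C@H]1CCCN1C(=O)C1(c2cccc(Cl)c2)CCCC1` gives 5.9. Compound 2 `O=C(Nc1ccc2[nH]ncc2n1)[C@H]1CCCN1C(=O)C1(c2ccc(F)cc2)CCC1` gives 4.1, the lower of the two numbers, and its gap to compound 1 lies beyond the usual scatter of repeated measurements. These two compounds differ in more than one place, so their gap cannot be tied to any one change.

Still unmeasured is compound 3 `COc1ccc(C2(C(=O)N3CCC[C@@H]3C(=O)Nc3ccc4[nH]ncc4n3)CCC2)cc1`, which matches compound 2 except for one group: methoxy in place of fluoro on an aromatic carbon. This puts methoxy in place of fluoro on an aromatic carbon, para to a large group. Going by the values given here, no measured pair here shows this swap, so the data give no direct guide to its size. With so little to go on, no shift beyond the scatter in this assay is expected, and any drift is expected to be slightly downward. The expected step is a number 0.10 log units lower from compound 2 to compound 3 (within the scatter), which stays within the scatter. Compound 3 is estimated at 4, with an expected range from 3.6 to 4.4.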

Compound 3, distribution coefficient: 3.9
Beside the measured number, compound 3's estimate is 0.10 log units above it; the range from low to high includes it.
By their numbers in this assay, from the lowest: compounds 3 and 2 (each within the scatter of the next); then compound 1.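

Going by these compounds alone, compound 3 forms the first pair that differs in only one place, so a single change can now be read directly in this assay. Replacing fluoro with methoxy on an aromatic carbon, para to a large group, gives a number 0.20 log units lower from compound 2 to compound 3 (within the scatter) and thus no measurable shift, even though the entering group brings one more heavy atom and one hydrogen-bond acceptor. At this position, then, 4-fluorophenyl and 4-methoxyphenyl cannot be told apart in this measurement, and nothing shown explains why.

On these data alone, what remains open is whether this holds for very different groups at the same position, such as an amine, a carboxylic acid or a longer chain like butoxy, or whether one of them would move the number beyond the scatter. This single pair also cannot show whether the same swap would behave alike on another member of the series, and the large gap between compound 1 and compound 2 still cannot be assigned to any one of their differences.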